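Series notes: amide substituent on the piperidine ring

The source may report more compounds than this note shows. Statements on the series, on what has been measured and on what is new or still open speak of the compounds shown alone.

Compound 1 `O=C(Nc1ccc(S(=O)(=O)N2CCCCC2)c2ccccc12)c1ccccc1` gives in an assay on L1.2 cells for binding affinity to C-C chemokine receptor type 8 (Homo sapiens) (a lower number here means a stronger inhibitor, a higher number a weaker inhibitor), only a limit, > 30000 nM, and this is the limit of > 30000 nM in this assay, at which 1 of the 2 values shown sits. Among the measured compounds shown here, compound 2 `Cc1ccccc1C(=O)Nc1ccc(S(=O)(=O)NC2CCN(C(=O)C3CCCC3)CC2)c2ccccc12` gives in this assay 9.1 nM, the only actual number so far. Compound 3 `Cc1ccccc1C(=O)Nc1ccc(S(=O)(=O)NC2CCN(C(=O)CCCN)CC2)c2ccccc12` differs from compound 2 by 3-aminopropyl in place of cyclopentyl on a carbonyl carbon. For the measured compounds named here, no measured pair shows such a change, so the expectation rests on compound 2 alone; a moderate loss, beyond the scatter, is expected for the step of a 3.8-fold higher number from compound 2 to compound 3 (0.59 log units; beyond the scatter). Compound 3 is therefore estimated at 35 nM, with a range from 6 nM to 250 nM.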

Compound 3, inhibition constant: 1.6 nM
For compound 3 the middle estimate is 22-fold (1.34 log units) above the measured one; measured number below the stated range.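

On the carbonyl carbon whose other neighbour is an amide-type nitrogen in a ring, the five-membered carbon ring of cyclopentyl is not required for activity in this assay. The open chain 3-aminopropyl, which brings one hydrogen-bond donor and one acceptor, gives a 5.7-fold lower number from compound 2 to compound 3 (0.75 log units; beyond the scatter). Nothing measured here accounts for this step.

Going by these compounds, whether the amine or the open chain carries the step remains open. A butyl chain, a 3-hydroxypropyl group or a longer aminoalkyl chain on this carbonyl carbon would separate the two.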